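Removing the ethyl group from compound 2

A few compounds are considered here, and "the series" means these few. Any claim that something is new, unique, unknown or untested is made for them only; others in the source may bear on it.

Measured so far:
compound 1 `Nc1cc(C2CCCC2)nc2ccc(NC(=O)/C=C/c3ccc(C(F)(F)F)cc3)cc12`: 0.8 nM
compound 2 `CCCc1cc(N)c2cc(NC(=O)/C=C/c3ccc(CC)cc3)ccc2n1`: 1.4 nM
compound 3 `CCCc1cc(N2CCC2)c2cc(NC(=O)/C=C/c3ccc(C(F)(F)F)cc3)ccc2n1`: 2.8 nM

In an assay on isolated protein for displacement of a labelled ligand from melanin-concentrating hormone receptor 1 (Homo sapiens) (a higher number here means a weaker inhibitor, a lower number a stronger inhibitor), compound 2 gives 1.4 nM. Its number is the second highest of the three. Compound 1 gives 0.8 nM and compound 3 gives 2.8 nM; both numbers lie within the usual scatter of the number for compound 2, so the three compounds cannot be told apart on these data.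

Compound 4 `CCCc1cc(N)c2cc(NC(=O)/C=C/c3ccccc3)ccc2n1` has not yet been measured. It differs from compound 2 in one place: hydrogen in place of ethyl on an aromatic carbon. The change removes the ethyl group that sits on the six-membered aromatic ring of carbon only, para to a large group, and leaves a hydrogen there. In the three measured compounds this position always carries a group, so the data give no direct guide to a bare ring.

The step from compound 2 to compound 4 is expected to be a modest increase in the number, as a 2.9-fold higher number from compound 2 to compound 4 (0.46 log units; beyond the scatter). For compound 4 the estimated value in this assay is 4 nM, within a range from 1.5 nM to 12 nM.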

Compound 4, half-maximal inhibitory concentration: 1000 nM
For compound 4 the middle estimate is 250-fold (2.40 log units) below the measured one; the measured number lies above the stated range.
By their numbers in this assay, from the lowest: compounds 1, 2 and 3 (each within the scatter of the next, the first and the last beyond it); then compound 4.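

In this assay removing the ethyl group alone gives a 710-fold higher number from compound 2 to compound 4 (2.85 log units; beyond the scatter) and so counts as a large step, well beyond the scatter. This position on the six-membered aromatic ring of carbon only is therefore no place where a group can simply be dropped: with the rest of the molecule unchanged, the change from 4-ethylphenyl to phenyl is enough to turn a low number into a far higher one. Nothing at hand explains why the bare ring falls so far.

Among the compounds shown, the only one-place step at this position links ethyl and hydrogen, so it stays open whether the size of the group or its kind matters. A methoxy group, a chlorine atom or a longer chain such as propyl in the same place would show how much of the lost strength returns.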